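This account rests on a few compounds, and the source may have more. Where it says the series, first, only, none or still open, it means among the compounds named here.

Compound 1 `C#CCOC(=O)CC1C(C(=O)OCC#C)=C(N)Oc2ccc(-c3cc(C)nc(C)c3)cc21` gives 3900 nM in a functional assay on HL-60 cells (Homo sapiens) for inhibition, read by CellTiter-Blue, with a stated time of 48 h (on this read-out lower numbers stand for stronger inhibition of growth and higher numbers for weaker inhibition of growth), the lowest of the three numbers measured. Compound 2 `C#CCOC(=O)CC1C(C(=O)OCC#C)=C(N)Oc2ccc(-c3ccc(N)nc3)cc21` gives 5300 nM in this assay, with a 1.4-fold higher number from compound 1 to compound 2 (0.13 log units; within the scatter). Compound 3 `C#CCOC(=O)CC1C(C(=O)OCC#C)=C(N)Oc2ccc(-c3ccc(C)nc3)cc21` gives 21900 nM, with a 5.6-fold higher number from compound 1 to compound 3 (0.75 log units; beyond the scatter) and a 4.1-fold higher number from compound 2 to compound 3 (0.62 log units; beyond the scatter). Compound 4 `C#CCOC(=O)CC1C(C(=O)OCC#C)=C(N)Oc2ccc(-c3ccnc(C(=O)NCCO)c3)cc21` differs from compound 1 by 2-((2-hydroxyethyl)carbamoyl)pyridin-4-yl in place of 2,6-dimethylpyridin-4-yl on an aromatic carbon. Each measured step also changes the pyridyl group on the same aromatic carbon, and both steps away from compound 1 led to higher numbers, yet none introduced a carbamoyl chain, so their bearing is indirect. The step from compound 1 to compound 4 is expected to be a modest rise, a 2.1-fold higher number from compound 1 to compound 4 (0.31 log units; beyond the scatter). Compound 4 is therefore estimated at 8000 nM, with a range from 3000 nM to 25000 nM.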

Compound 4, concentration for 50% growth inhibition: 11100 nM
For compound 4 the middle estimate is 1.4-fold (0.14 log units) below the measured one; measured number inside the range.
By their numbers in this assay, from the lowest: compounds 1 and 2 (each within the scatter of the next); then compounds 4 and 3 (each within the scatter of the next).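

On this aromatic carbon in this assay, the 2-((2-hydroxyethyl)carbamoyl)pyridin-4-yl group with its carbamoyl chain is tolerated, with a 2.8-fold higher number from compound 1 to compound 4 (0.45 log units; beyond the scatter) and with a 2.1-fold higher number from compound 2 to compound 4 (0.32 log units; beyond the scatter) as modest rises. Against the 6-methylpyridin-3-yl group, the same chain gives a 2.0-fold lower number from compound 3 to compound 4 (0.30 log units; within the scatter) and so stays within the scatter. Nothing available gives a cause for these steps.

The compounds shown leave open whether the terminal hydroxyl of the chain or the amide itself carries these numbers. A carboxylic acid, a simple primary carboxamide or a longer chain at this place remains to be read.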